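The source may report more compounds than this note shows. Statements on the series, on what has been measured and on what is new or still open speak of the compounds shown alone.

Measured so far:
compound 1 `Cc1ccc(O)c(C(O)(C(F)(F)F)C(F)(F)F)c1` — 207000 nM
compound 2 `Oc1c(-c2ccccc2)cccc1C(O)(C(F)(F)F)C(F)(F)F` — 157000 nM
compound 3 `CCCNC(=O)COc1ccc2cc(C(O)(C(F)(F)F)C(F)(F)F)c(O)cc2c1` — > 20000 nM

In an assay on isolated protein for inhibition of receptor-type tyrosine-protein phosphatase C (Homo sapiens), read by spectrophotometry (a lower number here means a stronger inhibitor, a higher number a weaker inhibitor), compound 1 gives 207000 nM and compound 2 gives 157000 nM. For compound 3 the read-out is not a number but a limit of the assay, > 20000 nM. Compound 3 thus sits at the limit of > 20000 nM in this assay, at which 1 of the 3 values shown sits, and its place among the three is known only as far as that limit reaches. Compound 4 `O=C(COc1ccc2cc(C(O)(C(F)(F)F)C(F)(F)F)c(O)cc2c1)NCc1ccc(F)cc1` carries the same core as compound 3; the change is 4-fluorophenyl in place of ethyl on a saturated chain carbon bound to an amide-type nitrogen. Among the compounds with values here, no pair of measured compounds shows a step of this kind, so the size of the step is open. Given that compound 3 reports only a limit, the expected step in this assay is an at least 1.6-fold lower number from compound 3 to compound 4 (0.22 log units; that floor lies within the scatter), a moderate gain, with a real chance that compound 4 too comes back only as a limit. Compound 4 is estimated at 12000 nM, with an expected range from 3000 nM to 50000 nM.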

Compound 4, half-maximal inhibitory concentration: > 20000 nM
Compound 4 gave a limit, no number; the forecaster's own chance of this, stated with the estimate: 45%; middle value at least 1.6-fold (0.22 log units) from the limit.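

In this assay compound 4 reads > 20000 nM, a limit of the assay. Compound 3 is also a limit, > 20000 nM. No step can be read from compound 3 to compound 4: the limit of > 20000 nM in this assay, at which 2 of the 4 values shown sit. The compounds shown leave open whether 4-fluorophenyl in place of ethyl changes inhibition at all.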